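This account rests on a few compounds, and the source may have more. Where it says the series, first, only, none or still open, it means among the compounds named here.

Measured in an ADME assay on a cell-free system (plasma, Rattus norvegicus, strain Sprague-Dawley) for metabolic stability, read by LC-MS, tested at 10 uM; a higher number here means that the compound lasts longer, a lower number that the compound disappears faster:
Compound 1 `O=C(NO)C(Cc1ccccc1)C(=O)NCc1ccc(F)cc1`: 0.8 h
Compound 2 `O=C(NO)/C(=C/c1ccccc1)C(=O)NCc1ccc(F)cc1`: 4.1 h

Compound 2, at 4.1 h, holds the higher of the two numbers, and the gap to compound 1, at 0.8 h, lies beyond the usual scatter. Compound 3 `O=C(NO)/C(=C\c1ccccc1)C(=O)NCc1ccc(F)cc1` keeps everything in compound 2 except the geometry: the two compounds have the same atoms and bonds and differ only in configuration as drawn: 1 of 1 stereo elements differ; a double bond is drawn E in compound 2 and Z in compound 3. Going by the values given here, no measured pair yet shows what such a switch does, so no step beyond the scatter is expected in this assay. The estimated change is a 1.4-fold lower number from compound 2 to compound 3 (0.14 log units; within the scatter). The expected half-life of compound 3 is 3 h, with a range from 1 h to 8 h.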

Compound 3, half-life in the plasma assay: 22 h
For compound 3 the middle estimate is 7.3-fold (0.87 log units) below the measured one; the measured number lies above the stated range.
By their numbers in the plasma assay, from the lowest: compound 1; then compound 2; then compound 3.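

In the plasma assay, turning the double bond from E to Z gives a 5.4-fold higher number from compound 2 to compound 3 (0.73 log units; beyond the scatter), so geometry alone can move this number beyond the scatter. The step can be tied to that switch because nothing else changes: the fact that compounds 2 and 3 differ only in the configuration as drawn. In a physicochemical assay for metabolic stability, in phosphate buffer, at pH 7.4 (a lower number here means that the compound disappears faster, a higher number that the compound lasts longer), compound 2 gives > 24 h, which is a limit of the assay. In the physicochemical assay compound 3 gives > 24 h, which is also a limit of the assay. In the physicochemical assay the same step cannot be read because of one limit: the limit of > 24 h in the physicochemical assay, at which 2 of the 2 values shown sit.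

Why the Z compound lasts longer in the plasma assay remains open. So does whether the switch would give a similar step with a carboxylic acid in place of the hydroxamic acid.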